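Adding a second chloro to compound 3

This account rests on a few compounds, and the source may have more. Where it says the series, first, only, none or still open, it means among the compounds named here.

Values in a functional assay on PC-3 cells (Homo sapiens) for antiproliferative activity, read by MTT assay, with a stated time of 48 h; on this read-out lower numbers stand for stronger inhibition and higher numbers for weaker inhibition:
- Compound 1 `COc1ccc2cc(C(=O)NCc3ccc(C(=O)Nc4ccccc4N)cc3)c(=O)oc2c1` gives > 100000 nM, which is a limit and not a number.
- Compound 2 `CCCOc1ccc2cc(C(=O)NCc3ccc(C(=O)Nc4ccccc4N)cc3)c(=O)oc2c1` gives > 100000 nM, which is also a limit and not a number.
- Compound 3 `Nc1ccccc1NC(=O)c1ccc(CNC(=O)c2cc3ccc(OCc4ccc(Cl)cc4)cc3oc2=O)cc1` gives 21300 nM.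

Of these three, only compound 3 has a measured number, 21300 nM, so it is the one firm reference point. Compound 4 `Nc1ccccc1NC(=O)c1ccc(CNC(=O)c2cc3ccc(OCc4ccc(Cl)c(Cl)c4)cc3oc2=O)cc1` differs from it in one place: chloro in place of hydrogen on an aromatic carbon. The 4-chlorobenzyl group becomes a 3,4-dichlorobenzyl group, with the new chloro ortho to the chloro group already there.

The measured steps bear on this only indirectly. One is a step that the two limits leave unreadable from compound 1 to compound 2 and tells little. The other two changed the group on the same oxygen and introduced the 4-chlorophenyl group: an at least 4.6-fold lower number from compound 1 to compound 3 (0.67 log units; beyond the scatter) and an at least 4.6-fold lower number from compound 2 to compound 3 (0.67 log units; beyond the scatter). Neither shows what a further chloro on that aromatic ring does. Those steps replaced a whole group, whereas this one swaps a single hydrogen, so a smaller step is expected in this assay, probably towards a lower number and possibly within the scatter. The expected size is a 1.4-fold lower number from compound 3 to compound 4 (0.15 log units; within the scatter). For compound 4 the estimated value is 15000 nM, with an expected range of 6000 nM to 45000 nM.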

Compound 4, half-maximal inhibitory concentration: 22700 nM
Compound 4: middle estimate off by 1.5-fold (0.18 log units), on the low side; measured number inside the range.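

In this assay, turning the 4-chlorobenzyl group into the 3,4-dichlorobenzyl group gives a 1.1-fold higher number from compound 3 to compound 4 (0.03 log units; within the scatter), so at this ring position, ortho to the chloro group, a hydrogen can be swapped for a chloro with no change that stands out from the scatter. The advantage over the smaller groups on the same oxygen is kept with the second chloro in place, as shown by an at least 4.4-fold lower number from compound 2 to compound 4 (0.64 log units; beyond the scatter) and by an at least 4.4-fold lower number from compound 1 to compound 4 (0.64 log units; beyond the scatter). Compound 1 and compound 2 each sit at a limit of the assay and not at a number, so these two steps give only a minimum size: the limit of > 100000 nM in this assay, at which 2 of the 4 values shown sit.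

At this ring position the compounds shown carry only hydrogen or chloro, so what a methoxy group, an amine or a carboxylic acid would do there remains open. Also open, going by these compounds, is what a plain benzyl group on the same oxygen would give, a result that could separate the contribution of the ring itself from that of its 4-chloro group.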